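The compounds below may be only part of what the source reports. "The series", "measured", "known", "first", "only" and "open" are said of these compounds alone.

Measured compounds:
compound 1 `CCCN(Cc1ccc(OCCN2C(=O)CCC2=O)c(OC)c1)C(C(=O)O)c1ccc(Cl)cc1` gives 256 nM
compound 2 `CCCN(Cc1ccc(OCCN2C(=O)CCC2=O)c(C)c1)C1c2ccc(Cl)cc2CC1C(=O)O` gives 1350 nM
compound 3 `Cc1cc(CN(CC2CC2)C(CC(=O)O)c2ccc(Cl)cc2)ccc1OCCN1C(=O)CCC1=O` gives 65 nM

These three compounds were tested in an assay on CHO cells for displacement of a labelled ligand from C-X-C chemokine receptor type 3 (Homo sapiens), with a stated time of 60 min; a lower number here means a stronger inhibitor, a higher number a weaker inhibitor. Compound 3 gives the lowest number of the three, and the numbers of compound 1 and compound 2 both lie beyond the scatter above it, compound 2 furthest away. Compound 4 `Cc1cc(CN(CC2CCCCC2)C(CC(=O)O)c2ccc(Cl)cc2)ccc1OCCN1C(=O)CCC1=O` has not yet been measured. It differs from compound 3 in one place: cyclohexyl in place of cyclopropyl on a saturated chain carbon bound to an amine nitrogen. No pair among the measured compounds carries this change, so its direction is not shown by the data. The expectation for compound 4 is a small step, a 1.8-fold higher number from compound 3 to compound 4 (0.27 log units; within the scatter), not clearly beyond the scatter in this assay. Compound 4 is therefore estimated at 120 nM, with a range from 30 nM to 500 nM.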

Compound 4, half-maximal inhibitory concentration: 81 nM
Estimate against measurement, compound 4: 1.5-fold (0.17 log units) above, and the stated range covers the measured number.
By their numbers in this assay, from the lowest: compounds 3 and 4 (each within the scatter of the next); then compound 1; then compound 2.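

In this assay cyclohexyl in place of cyclopropyl on a saturated chain carbon bound to an amine nitrogen gives a 1.2-fold higher number from compound 3 to compound 4 (0.10 log units; within the scatter) and so leaves compound 3 and compound 4 inseparable. Among the compounds shown here, this is the first step that can be read at this position, and it shows that the larger of these two carbon rings can stand there without moving the number beyond the scatter. Nothing available explains this result. From the compounds shown here alone, whether a phenyl ring, or a cyclohexyl carrying a hydroxyl or an amine, would hold the number at this position stays open.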